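The source may report more compounds than this note shows. Statements on the series, on what has been measured and on what is new or still open speak of the compounds shown alone.

Working notes on the series.

The common core is an oxindole bearing an ethyl group and a butyl chain that ends in an arylpiperazine; the compounds differ only in the aryl group on the piperazine. In a functional assay on the whole organism (strain Wistar) with Rattus norvegicus as the target, with a stated time of 5 min (a higher number here means that more compound is needed for the effect, a lower number that less compound is needed), compound 2 `CCC1(CCCCN2CCN(c3ccc(Cl)cc3)CC2)C(=O)Nc2ccccc21` gives 10 mg/kg. For compound 1 `CCC1(CCCCN2CCN(c3ccc(Cl)c(Cl)c3)CC2)C(=O)Nc2ccccc21` only a limit of this assay is known, > 20 mg/kg. Compound 3 `CCC1(CCCCN2CCN(c3ccccc3Cl)CC2)C(=O)Nc2ccccc21` likewise returns only a limit, > 20 mg/kg. Compound 3 thus stands at the upper boundary of what this assay reports, sharing that position with compound 1, as noted in the limit of > 20 mg/kg in this assay, at which 2 of the 3 values shown sit.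

The step to compound 4 `CCC1(CCCCN2CCN(c3cccc(Cl)c3)CC2)C(=O)Nc2ccccc21` is 3-chlorophenyl in place of 2-chlorophenyl on an amine nitrogen in a ring. Among the compounds with values here, no measured step moves a single chlorine into this position, so the expectation rests on neighbouring steps: an at least 2.0-fold higher number from compound 2 to compound 3 (0.30 log units; that floor lies within the scatter), and an at least 2.0-fold lower number from compound 1 to compound 2 (0.30 log units; that floor lies within the scatter). Both lie at the floor of the scatter and both are one-sided, so the read is weak. Compound 1 carries chlorine in the 3-position together with the 4-position and sits at the limit, while compound 2 without it gives a number.

For compound 4 the estimate is 20 mg/kg, with a range of 8 mg/kg to 40 mg/kg; the step from compound 3 implied by this estimate, a number no higher from compound 3 to compound 4 (the limit leaves the size open), is expected to be small and may well return another limit.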

Compound 4, minimum effective dose: > 20 mg/kg
Compound 4 gave a limit, no number; the forecaster's own chance of this, stated with the estimate: 55%; the middle value sits exactly at the limit.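

The change to 3-chlorophenyl from 4-chlorophenyl gives in this assay an at least 2.0-fold higher number from compound 2 to compound 4 (0.30 log units; that floor lies within the scatter); this floor lies within the scatter, so the step alone does not establish a real difference. The value of compound 4 is a limit, as are those of compound 1 and compound 3, and the steps among these three cannot be read. Among the compounds shown, 4-chlorophenyl is now the only aryl group that returns a number, whereas 2-chlorophenyl, 3-chlorophenyl and 3,4-dichlorophenyl all end at the same boundary: the limit of > 20 mg/kg in this assay, at which 3 of the 4 values shown sit.

What number lies behind each limit stays open, so 2-chlorophenyl and 3-chlorophenyl cannot be placed in order, and neither can be ranked against 3,4-dichlorophenyl. Also open, from the compounds shown here alone, is whether the number seen with 4-chlorophenyl depends on chlorine itself, which 4-fluorophenyl, 4-methoxyphenyl or plain phenyl on the same ring nitrogen would help to settle.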